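Propyl to allyl on the aromatic nitrogen: cytotoxicity outlook

This account rests on a few compounds, and the source may have more. Where it says the series, first, only, none or still open, it means among the compounds named here.

Measured compounds:
- compound 1 `CCCN(c1ccnc(Nc2ccc(C#N)cc2)n1)c1c(F)cc(-c2ccc(C#N)cc2)cc1F` gives 212000 nM in an ADME assay on MT4 cells (Homo sapiens) for cytotoxicity, read by MTT assay, with a stated time of 5 days; on this read-out lower numbers stand for higher toxicity in this test and higher numbers for lower toxicity in this test
- compound 2 `CCCCN(c1ccnc(Nc2ccc(C#N)cc2)n1)c1c(F)cc(-c2ccc(C#N)cc2)cc1F` gives 211000 nM in this assay
- compound 3 `N#Cc1ccc(Nc2nccc(N(c3c(F)cc(-c4ccc(C#N)cc4)cc3F)C3CCCC3)n2)cc1` gives 232000 nM in this assay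

Compound 1 holds the second highest of the three numbers in this assay; its nearest neighbour is compound 2 and its furthest is compound 3, and both lie within the scatter of it. Compound 4 `C=CCN(c1ccnc(Nc2ccc(C#N)cc2)n1)c1c(F)cc(-c2ccc(C#N)cc2)cc1F` carries the change (vinyl in place of ethyl on a saturated chain carbon bound to a nitrogen on an aromatic ring); cut one bond further out, the same difference reads propyl to allyl.

Two measured steps alter the same group on the aromatic nitrogen. The step of a 1.0-fold lower number from compound 1 to compound 2 (0.00 log units; within the scatter) and the step of a 1.1-fold higher number from compound 1 to compound 3 (0.04 log units; within the scatter) both stay within the scatter, and the step of a 1.1-fold higher number from compound 2 to compound 3 (0.04 log units; within the scatter) does the same. Among the measured compounds shown here, every change at this position so far has left this assay untouched, so no step beyond the scatter is expected for compound 4. The expected step is a 1.0-fold higher number from compound 1 to compound 4 (0.01 log units; within the scatter). Compound 4 is therefore estimated at 215000 nM in this assay, with a range from 130000 nM to 350000 nM.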

Compound 4, half-maximal cytotoxic concentration: 249000 nM
Beside the measured number, compound 4's estimate is 1.2-fold (0.06 log units) below it, and the stated range covers the measured number.
By their numbers in this assay, from the lowest: compounds 2, 1, 3 and 4 (each within the scatter of the next).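

Allyl brings the first double bond outside aromatic rings to the group on the aromatic nitrogen, and in this assay this leaves the read-out within the scatter: the comparison with propyl gives a 1.2-fold higher number from compound 1 to compound 4 (0.07 log units; within the scatter) and the comparison with butyl gives a 1.2-fold higher number from compound 2 to compound 4 (0.07 log units; within the scatter). Against the ring-bearing cyclopentyl, allyl gives a 1.1-fold higher number from compound 3 to compound 4 (0.03 log units; within the scatter), so all four groups shown on this nitrogen, saturated or not and open-chain or ring, stay within the scatter of one another in this assay. No measurement on hand explains this flat response.

Going by these compounds, whether this position tolerates every group remains open, as the set holds only hydrocarbon groups on this nitrogen. A terminal amine, a carboxylic acid or a benzyl group there could still give a step beyond the scatter in this assay.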